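The source may report more compounds than this note shows. Statements on the series, on what has been measured and on what is new or still open speak of the compounds shown alone.

Compound 1 `O=C(CN1CCN(c2nnc(Cc3ccncc3)c3ccccc23)CC1)Nc1cccc(Br)c1` gives 1350 nM in a functional assay on HT-29 cells (Homo sapiens) for cytotoxicity, read by MTT assay, with a stated time of 72 h; a higher number here means a weaker inhibitor, a lower number a stronger inhibitor.
Compound 2 `O=C(CN1CCN(c2nnc(Cc3ccncc3)c3ccccc23)CC1)Nc1ccc(F)c(Cl)c1` gives 880 nM.
Compound 3 `O=C(CN1CCN(c2nnc(Cc3ccccc3)c3ccccc23)CC1)Nc1ccc(F)c(Cl)c1` gives 13300 nM.

Compound 1 and compound 2 share a core and differ by 3-bromophenyl in place of 3-chloro-4-fluorophenyl on an amide-type nitrogen; this gave a 1.5-fold higher number from compound 2 to compound 1 (0.19 log units; within the scatter). The two cores differ by phenyl in place of pyridin-4-yl on a saturated chain carbon bound to an aromatic carbon, and that change gave a 15-fold higher number from compound 2 to compound 3 (1.18 log units; beyond the scatter), leaving compound 3 with the highest number of the three.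

Compound 4 `O=C(CN1CCN(c2nnc(Cc3ccccc3)c3ccccc23)CC1)Nc1cccc(Br)c1` is not yet measured. It differs from compound 3 by 3-bromophenyl in place of 3-chloro-4-fluorophenyl on an amide-type nitrogen, the same change that turns compound 2 into compound 1, at a place described in the same words. That earlier change produced only a 1.5-fold higher number from compound 2 to compound 1 (0.19 log units; within the scatter), so the number for compound 4 is expected to stay near that of compound 3. The expected step to compound 4 is a 1.4-fold higher number from compound 3 to compound 4 (0.13 log units; within the scatter). The estimate for compound 4 in this assay is 18000 nM, likely between 7000 nM and 45000 nM.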

Compound 4, half-maximal inhibitory concentration: 13400 nM
Compound 4: middle estimate off by 1.3-fold (0.13 log units), on the high side; low and high end bracket the measured number.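

Replacing 3-chloro-4-fluorophenyl with 3-bromophenyl on the amide-type nitrogen again leaves the number in this assay within the scatter, with a 1.0-fold higher number from compound 3 to compound 4 (0.00 log units; within the scatter), and the two cores respond alike: the same change on two cores in this assay, a 1.5-fold higher number (0.19 log units; within the scatter) from compound 2 to compound 1 and a 1.0-fold higher number (0.00 log units; within the scatter) from compound 3 to compound 4, 1.5-fold (0.18 log units) apart, within the scatter of two such steps. Replacing pyridin-4-yl with phenyl also carries over, with a 9.9-fold higher number from compound 1 to compound 4 (1.00 log units; beyond the scatter), and its size holds with either group on the amide-type nitrogen: the same change on two cores in this assay, a 15-fold higher number (1.18 log units; beyond the scatter) from compound 2 to compound 3 and a 9.9-fold higher number (1.00 log units; beyond the scatter) from compound 1 to compound 4, 1.5-fold (0.18 log units) apart, within the scatter of two such steps. Among these compounds, this rests on only two pairs for each change, so it does not show that either change would carry over to a different core or to other groups.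

The compounds shown leave open how a pyridin-3-yl group would compare with pyridin-4-yl at that position. They also leave open whether a 4-methoxyphenyl group on the amide-type nitrogen would behave like the two groups shown here.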